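Phenyl for Furan-2-yl: Expected Cytotoxicity of Compound 4

This account rests on a few compounds, and the source may have more. Where it says the series, first, only, none or still open, it means among the compounds named here.

Compound 2 `Oc1ccc(-c2cc(-c3ccc(Cl)cc3)nc(-c3ccco3)c2)cc1` gives 5720 nM in an ADME assay on HEK293 cells (Homo sapiens) for cytotoxicity, read by CCK-8 assay and cell counting, with a stated time of 2 days; a higher number here means a weaker inhibitor, a lower number a stronger inhibitor. Compound 1 `Oc1ccc(-c2cc(-c3ccccc3)nc(-c3ccc(Cl)cc3)c2)cc1` differs from it by phenyl in place of furan-2-yl on an aromatic carbon and gives 4810 nM in this assay, a step of a 1.2-fold lower number from compound 2 to compound 1 (0.08 log units; within the scatter). Compound 3 `Oc1ccc(-c2cc(-c3cccc(Cl)c3)nc(-c3ccco3)c2)cc1` differs from compound 2 by 3-chlorophenyl in place of 4-chlorophenyl on an aromatic carbon, a step of a 2.0-fold lower number from compound 2 to compound 3 (0.30 log units; within the scatter). In this assay compound 3 gives 2880 nM. Compound 4 `Oc1ccc(-c2cc(-c3ccccc3)nc(-c3cccc(Cl)c3)c2)cc1` differs from compound 3 by phenyl in place of furan-2-yl on an aromatic carbon. This is the same kind of change as that from compound 2 to compound 1, though the place is not identical: there the site was meta to a 4-chlorophenyl group, here it is meta to a 3-chlorophenyl group. Because the earlier step of a 1.2-fold lower number from compound 2 to compound 1 (0.08 log units; within the scatter) lay within the scatter, compound 4 is expected to show a similarly small step of a 1.2-fold lower number from compound 3 to compound 4 (0.08 log units; within the scatter). Compound 4 is therefore estimated at 2400 nM, between 1200 nM and 4800 nM.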

Compound 4, half-maximal inhibitory concentration: 2820 nM
Compound 4: middle estimate off by 1.2-fold (0.07 log units), on the low side; low and high end bracket the measured number.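

Phenyl in place of furan-2-yl gives a 1.0-fold lower number from compound 3 to compound 4 (0.01 log units; within the scatter), and the step carries across the two cores: the same change on two cores in this assay, a 1.2-fold lower number (0.08 log units; within the scatter) from compound 2 to compound 1 and a 1.0-fold lower number (0.01 log units; within the scatter) from compound 3 to compound 4, 1.2-fold (0.07 log units) apart, within the scatter of two such steps. 3-Chlorophenyl in place of 4-chlorophenyl gives a 1.7-fold lower number from compound 1 to compound 4 (0.23 log units; within the scatter), and this change also carries across: the same change on two cores in this assay, a 2.0-fold lower number (0.30 log units; within the scatter) from compound 2 to compound 3 and a 1.7-fold lower number (0.23 log units; within the scatter) from compound 1 to compound 4, 1.2-fold (0.07 log units) apart, within the scatter of two such steps. All four steps lie within the scatter of this assay, so the series shows that neither change gave a readable shift on either core, not that either has a real effect that transfers from one core to another.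

The compounds leave open whether a step beyond the scatter would carry over in the same way. They also leave open what an amine or a carboxylic acid at the furan-2-yl site, or a methoxy group in place of the hydroxyl of the 4-hydroxyphenyl group, would do.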